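A few compounds are considered here, and "the series" means these few. Any claim that something is new, unique, unknown or untested is made for them only; others in the source may bear on it.

Measured so far:
- Compound 1 `CC(C)=CCC/C(C)=C/CC/C(C)=C/CC[C@]1(C)CCc2cc(OC(=O)c3cc(C(=O)O)ccc3C(=O)O)cc(C)c2O1`: 1500 nM
- Compound 2 `CC(C)=CCC/C(C)=C/CC/C(C)=C/CC[C@]1(C)CCc2cc(OC(=O)/C=C\C(=O)O)c(C)c(C)c2O1`: 2300 nM

In a functional assay on cells (+SA cell, Mus musculus) for cytotoxicity, read by MTT assay, with a stated time of 24 h (on this read-out lower numbers stand for stronger inhibition and higher numbers for weaker inhibition), compound 2 gives 2300 nM, within the usual scatter of compound 1 at 1500 nM. Compound 3 `CC(C)=CCC/C(C)=C/CC/C(C)=C/CC[C@]1(C)CCc2cc(OC(=O)/C=C\C(=O)O)cc(C)c2O1` departs from compound 2 by one change, hydrogen in place of methyl on an aromatic carbon. For the measured compounds named here, no measured pair isolates this change, and the two values so far lie close together, so only a small shift, none beyond the scatter, is expected. The expected result is a 1.4-fold lower number from compound 2 to compound 3 (0.13 log units; within the scatter). For compound 3 the estimated value is 1700 nM, with an expected range of 750 nM to 3800 nM.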

Compound 3, half-maximal inhibitory concentration: 870 nM
Compound 3: middle estimate off by 2.0-fold (0.29 log units), on the high side, within the range that was stated.
By their numbers in this assay, from the lowest: compounds 3, 1 and 2 (each within the scatter of the next, the first and the last beyond it).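

In this assay, for the compounds shown here, hydrogen in place of methyl on the aromatic carbon ortho to the ((2-carboxyethenyl)carbonyl)oxy group gives a 2.6-fold lower number from compound 2 to compound 3 (0.42 log units; beyond the scatter), the first single-place step at this position and one beyond the scatter. By contrast, 2-carboxyethenyl in place of 2,5-dicarboxyphenyl on a carbonyl carbon gives a 1.7-fold lower number from compound 1 to compound 3 (0.24 log units; within the scatter), which stays within the scatter. Nothing available explains either step.

From the compounds shown here alone, what an ethyl, a methoxy or a chlorine would give at this aromatic carbon stays open. Also open, going by these compounds, is whether the methyl step carries over to compounds bearing the 2,5-dicarboxyphenyl group.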